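Will a substituted phenyl change what cells tolerate?

The source may report more compounds than this note shows. Statements on the series, on what has been measured and on what is new or still open speak of the compounds shown alone.

Compound 1 `c1ccc(-c2cnnc(NCc3cc(-c4ccccc4)[nH]n3)n2)cc1`: > 10000 nM
Compound 2 `Cc1ccccc1-c1cccc(NCc2cc(-c3ccccc3)[nH]n2)c1`: > 10000 nM

Both compounds were tested in an ADME assay on CEM174 cells (Homo sapiens) for cytotoxicity; a lower number here means that less compound is tolerated, a higher number that more compound is tolerated. In this assay compound 1 gives > 10000 nM, which is a limit of the assay and not a number. Compound 2 stands in the same place, so the two can't be ranked: the limit of > 10000 nM in this assay, at which 2 of the 2 values shown sit.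

The next compound to be measured is compound 3 `Cc1cc(C#N)ccc1-c1cnnc(NCc2cc(-c3ccccc3)[nH]n2)n1`. It keeps the core of compound 1 but carries 4-cyano-2-methylphenyl in place of phenyl on an aromatic carbon.

Within the data shown here, no pair of measured compounds differs in one place only, so no measured step can guide the forecast. The expectation rests on compound 1 and compound 2, which show (the limit of > 10000 nM in this assay, at which 2 of the 2 values shown sit). Nothing beyond the scatter is expected in this assay, in either direction, and the assay may well report only a limit again. The estimated change is a step that the limit leaves unreadable from compound 1 to compound 3. For compound 3 the expected value is 15000 nM, with an estimated range from 5000 nM to 50000 nM.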

Compound 3, half-maximal cytotoxic concentration: > 10000 nM
Compound 3 ended at the assay's limit (the forecaster's own chance of this, stated with the estimate: 70%); the middle value lies beyond the limit too.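

Compound 1 and compound 3 both end at a limit of this assay, not at a number, so no step between them can be read: the limit of > 10000 nM in this assay, at which 3 of the 3 values shown sit.

How much of any of these compounds the cells tolerate remains open, as does whether 4-cyano-2-methylphenyl in place of phenyl changes that at all.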